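The source may report more compounds than this note shows. Statements on the series, on what has been measured and on what is new or still open speak of the compounds shown alone.

Values in a functional assay on HepG2 cells (Homo sapiens) for inhibition, read by MTT assay, with a stated time of 72 h (on this read-out lower numbers stand for stronger inhibition and higher numbers for weaker inhibition), by compound:
compound 1 `C#CCSc1nc(Nc2ccccc2Cl)c2ccncc2n1` gives 17200 nM
compound 2 `C#CCSc1nc(Nc2ccc(Cl)cc2Cl)c2ccncc2n1` gives 11000 nM
compound 3 `C#CCSc1nc(Nc2ccccc2OC)c2ccncc2n1` gives 4530 nM
compound 4 `C#CCSc1nc(Nc2cccc(O)c2)c2ccncc2n1` is not yet measured

Compound 1 stands in the upper part of these numbers, and a 1.6-fold lower number from compound 1 to compound 2 (0.19 log units; within the scatter) marks its nearest neighbour. For the measured compounds named here, the change under study is 3-hydroxyphenyl in place of 2-chlorophenyl on a nitrogen on an aromatic ring and no measured compound carries 3-hydroxyphenyl yet. Going by the values given here, two measured steps bear on it only indirectly. Chloro in place of hydrogen on an aromatic carbon gives a 1.6-fold lower number from compound 1 to compound 2 (0.19 log units; within the scatter) and so offers little guidance. Methoxy in place of chloro on an aromatic carbon gives a 3.8-fold lower number from compound 1 to compound 3 (0.58 log units; beyond the scatter) and is the closer precedent, as chloro also leaves on the way to compound 4. A hydroxy group is not a methoxy group, so this precedent carries over only loosely. In this assay, among the compounds with values here, a modest move towards a lower number is therefore expected, no larger than that precedent. The estimated step is a 2.3-fold lower number from compound 1 to compound 4 (0.36 log units; beyond the scatter) and it remains uncertain. For compound 4 the estimate is 7500 nM and the expected range runs from 2500 nM to 20000 nM as a working figure.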

Compound 4, half-maximal inhibitory concentration: 29500 nM
For compound 4 the middle estimate is 3.9-fold (0.59 log units) below the measured one, outside the stated range (above it).
By their numbers in this assay, from the lowest: compound 3; then compounds 2, 1 and 4 (each within the scatter of the next, the first and the last beyond it).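

In this assay, 3-hydroxyphenyl in place of 2-chlorophenyl on a nitrogen on an aromatic ring gives a 1.7-fold higher number from compound 1 to compound 4 (0.23 log units; within the scatter), so this exchange stays within the scatter, unlike the methoxy exchange, which gives a 3.8-fold lower number from compound 1 to compound 3 (0.58 log units; beyond the scatter). At this place, then, a hydrogen-bond donor enters with 3-hydroxyphenyl without a step beyond the scatter, and the step seen for compound 3 does not carry over to compound 4. Nothing available accounts for this difference between the two exchanges.

The compounds shown leave open whether the step to compound 3 belongs to methoxy itself or to where that group sits on the phenyl ring. They also leave open how an amine or a carboxylic acid on the phenyl ring would read in this assay.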